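Replacing the amine methyl by ethyl on a methylene core

A few compounds are considered here, and "the series" means these few. Any claim that something is new, unique, unknown or untested is made for them only; others in the source may bear on it.

Of the compounds shown here, three have been measured in a functional assay on HCT-8 cells (Homo sapiens) for antiproliferative activity, read by MTT assay, with a stated time of 48 h; on this read-out higher numbers stand for weaker inhibition and lower numbers for stronger inhibition. Compound 1 `CNCC(=O)Nc1cc(OC)ccc1C(=O)c1ccc(OC)c2c1C=CC(C)(C)O2` gives 3460 nM in this assay, and compound 2 `CCNCC(=O)Nc1cc(OC)ccc1C(=O)c1ccc(OC)c2c1C=CC(C)(C)O2` gives 7890 nM. The step between them, a 2.3-fold higher number from compound 1 to compound 2 (0.36 log units; beyond the scatter), is the change (methyl in place of hydrogen on a saturated chain carbon bound to an amine nitrogen); it is a modest loss of potency that nevertheless lies beyond the usual scatter. Compound 3 `C=C(c1ccc2c(c1)C=CC(C)(C)O2)c1ccc(OC)cc1NC(=O)CNC` rests on a different core, and the difference between the two cores is not broken down here. In this assay compound 3 gives 590 nM, the lowest number of the three measured compounds, standing well apart from both compound 1 and compound 2.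

Compound 4 `C=C(c1ccc2c(c1)C=CC(C)(C)O2)c1ccc(OC)cc1NC(=O)CNCC` has not yet been measured. It differs from compound 3 by methyl in place of hydrogen on a saturated chain carbon bound to an amine nitrogen, which is the same change, at the same kind of place, as the one that separates compound 1 from compound 2; within the compounds shown, this change occurs twice in all. Because compound 2 shows a weakening relative to compound 1 of a 2.3-fold higher number from compound 1 to compound 2 (0.36 log units; beyond the scatter), a comparable weakening is expected from compound 3 to compound 4, a 2.2-fold higher number from compound 3 to compound 4 (0.34 log units; beyond the scatter). Among the compounds with values here, on that basis compound 4 is estimated to give 1300 nM in this assay, with a plausible range from 600 nM to 3000 nM; the single precedent leaves this estimate uncertain.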

Compound 4, half-maximal inhibitory concentration: 2220 nM
Compound 4: middle estimate off by 1.7-fold (0.23 log units), on the low side, and the stated range covers the measured number.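

On the second core, replacing the amine methyl by ethyl gives a 3.8-fold higher number from compound 3 to compound 4 (0.58 log units; beyond the scatter) in this assay, so the loss of potency seen on the first core appears here as well. The two steps point the same way, and the gap between them is no larger than repeated measurements of such steps would allow: the same change on two cores in this assay, a 2.3-fold higher number (0.36 log units; beyond the scatter) from compound 1 to compound 2 and a 3.8-fold higher number (0.58 log units; beyond the scatter) from compound 3 to compound 4, 1.7-fold (0.22 log units) apart, within the scatter of two such steps. This shows that the change carried over between this one pair of cores in this one assay, but two steps cannot show that it would behave alike on any further core, and they do not explain why the ethylamino group gives the higher number.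

The compounds shown cover only the methylamino and ethylamino groups, so they leave open whether a longer chain such as propyl, a branched group such as isopropyl, or a ring amine such as pyrrolidine would weaken inhibition further on either core. They also leave open how an unsubstituted primary amine at the same place would compare, and whether such a group would give similar steps on the two cores.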